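The source may hold more compounds than are shown below. What is called first, only, known or untested is meant among the compounds shown, and "the series" means these compounds.

Working notes on the series. Among the compounds with values here, compound 1 `CC(C)(NC(=O)OCc1ccccc1)c1nc(O)c(O)c(NC(=O)NCc2ccc(F)cc2)n1` is the only member with a measured number in an ADME assay on C8166 cells (Homo sapiens) for cytotoxicity, read by MTT assay, with a stated time of 3 days; a lower number here means that less compound is tolerated, a higher number that more compound is tolerated: compound 1 gives 81100 nM. Compound 2 `CC(C)(NC(=O)OCc1ccccc1)c1nc(O)c2oc(=O)[nH]c2n1` does not yield a number in this assay; for compound 2 the read-out is a limit of the assay, > 500000 nM, and nothing more is known of it than that it is a limit. Thus compound 1 stands as the single measured value, with the other entry sitting at the limit of > 500000 nM in this assay, at which 1 of the 2 values shown sits. Compound 3 `COCCNC(=O)Nc1nc(C(C)(C)NC(=O)OCc2ccccc2)nc(O)c1O` is not yet measured in this assay. Compound 3 differs from compound 1 in one place: methoxymethyl in place of 4-fluorophenyl on a saturated chain carbon bound to an amide-type nitrogen; methoxymethyl in place of 4-fluorophenyl on a saturated chain carbon bound to an amide-type nitrogen. Within the data shown here, no step between two measured compounds is available to calibrate this change, so the expectation for compound 3 rests on compound 1 alone. The expected step in this assay, a 1.5-fold higher number from compound 1 to compound 3 (0.17 log units; within the scatter), is small and, if anything, toward a higher tolerated concentration, without confidence that it exceeds the scatter. For compound 3 the estimate in this assay is 120000 nM, with a range from 45000 nM to 400000 nM.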

Compound 3, half-maximal cytotoxic concentration: > 500000 nM
Compound 3 gave a limit, no number (the forecaster's own chance of this, stated with the estimate: 25%); middle value at least 4.1-fold (0.61 log units) away from the limit.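

At the saturated chain carbon bound to an amide-type nitrogen, the series now has its first step in this assay, and that step is an at least 6.1-fold higher number from compound 1 to compound 3 (0.78 log units; beyond the scatter). Methoxymethyl in place of 4-fluorophenyl, which removes the six-membered aromatic ring and adds one hydrogen-bond acceptor, is thus a single change that moves the read-out beyond the scatter, so this position is not silent in this assay. The step has a lower bound but no upper one, since compound 3 gives a limit and not a number, and the measured range of the series is now bounded by that same limit: the limit of > 500000 nM in this assay, at which 2 of the 3 values shown sit.

The compounds shown do not tell whether the shift follows from the loss of the aromatic ring or from the gain of the ether oxygen, a question that a plain butyl chain or a cyclohexylmethyl group at this place could separate. From the compounds shown here alone, how an amine or a carboxylic acid at the end of the chain would read in this assay also stays open, as does any ranking among groups that reach the limit.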